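Working notes: adding fluorine to the benzyl group of compound 2

The compounds below may be only part of what the source reports. "The series", "measured", "known", "first", "only" and "open" are said of these compounds alone.

In a functional assay on Bel7402/5-FU cells (Homo sapiens) for antiproliferative activity, read by MTT assay, with a stated time of 72 h (a higher number here means a weaker inhibitor, a lower number a stronger inhibitor), compound 1 `C=C1C(=O)O[C@H]2[C@H]1CC/C(COC(=O)CCC(=O)N1CCN(C(=O)Cn3cc(F)c(=O)[nH]c3=O)CC1)=C\CC[C@@]1(C)O[C@@H]21` gives > 20000 nM and this is a limit of the assay, not a number. Compound 2 `C=C1C(=O)O[C@H]2[C@H]1CC/C(COC(=O)Cn1cc(F)c(=O)n(Cc3ccccc3)c1=O)=C\CC[C@@]1(C)O[C@@H]21` reads 4270 nM in the same test. Compound 3 `C=C1C(=O)O[C@H]2[C@H]1CC/C(Cn1cc(Cn3cc(F)c(=O)n(Cc4ccc(F)cc4)c3=O)nn1)=C\CC[C@@]1(C)O[C@@H]21` reads 4860 nM there. Going by the values given here, the values of compound 2 and compound 3 lie within the scatter of each other, so compound 2 stands level with compound 3, and these are the only two true numbers in hand.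

Compound 4 `C=C1C(=O)O[C@H]2[C@H]1CC/C(COC(=O)Cn1cc(F)c(=O)n(Cc3ccc(F)cc3F)c1=O)=C\CC[C@@]1(C)O[C@@H]21` has not yet been measured. Its difference from compound 2 is 2,4-difluorophenyl in place of phenyl on a saturated chain carbon bound to an aromatic nitrogen and, in words, it is 2,4-difluorophenyl in place of phenyl on a saturated chain carbon bound to an aromatic nitrogen.

Among the compounds with values here, no measured step isolates this change. The expectation leans on compound 3 (4860 nM), which also carries a fluorinated benzyl group, differs from compound 2 elsewhere as well, and still reads level with it. A small shift toward a lower number is expected, most likely not beyond the scatter, and the estimated step runs a 1.2-fold lower number from compound 2 to compound 4 (0.09 log units; within the scatter) in this assay.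

For compound 4 the estimated value is 3500 nM with an expected range of 1400 nM to 8500 nM.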

Compound 4, half-maximal inhibitory concentration: 5010 nM
Estimate against measurement, compound 4: 1.4-fold (0.16 log units) below, within the range that was stated.
By their numbers in this assay, from the lowest: compounds 2, 3 and 4 (each within the scatter of the next). At a limit, above all of these: compound 1.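

In this assay, 2,4-difluorobenzyl in place of benzyl leaves the read-out level, with a 1.2-fold higher number from compound 2 to compound 4 (0.07 log units; within the scatter). Going by these compounds alone, this is the only step that isolates a change at this place, on a saturated chain carbon bound to an aromatic nitrogen, whereas compound 3 differs from compound 2 elsewhere as well and could not separate the fluorine atoms from its other differences. With the rest of compound 2 held constant, 2,4-difluorophenyl and phenyl therefore cannot be told apart in this test, and nothing in hand bears on why the step is so small.

On these data alone, the phenyl and 2,4-difluorophenyl groups at this place have similar ring structures, so it remains open whether an amine, a carboxylic acid or a longer chain in their stead would move the number beyond the scatter. Within the data shown here, it also remains open whether 2,4-difluorobenzyl would read level with benzyl on a core other than that of compound 2, since only this one pair carries the comparison.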